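Series notes: replacing the 2-chlorophenyl group in compound 1

This account rests on a few compounds, and the source may have more. Where it says the series, first, only, none or still open, it means among the compounds named here.

Among the compounds with values here, compound 1 `Cc1cc(O)c(C(C)C)cc1-c1cc(-c2ccccc2Cl)c(C#N)c(=O)[nH]1` gives 20% in a functional assay for inhibition, tested at 40 ug/mL (a higher number here means a stronger effect of the compound at the concentration tested, a lower number a weaker effect), the lowest of the three numbers so far; the gap to compound 3 lies within the scatter, the gap to compound 2 beyond it. Compound 2 `COc1ccc(-c2cc(-c3cc(C(C)C)c(O)cc3C)[nH]c(=O)c2C#N)cc1OC` gives 44% in this assay, and compound 3 `COc1cccc(-c2cc(-c3cc(C(C)C)c(O)cc3C)[nH]c(=O)c2C#N)c1` gives 30%. The two measured steps away from the 2-chlorophenyl group are a number 24 percentage points higher from compound 1 to compound 2 (beyond the scatter) and a number 10 percentage points higher from compound 1 to compound 3 (within the scatter). Compound 4 `Cc1cc(O)c(C(C)C)cc1-c1cc(-c2ccc(N(C)C)cc2)c(C#N)c(=O)[nH]1` makes a third such exchange: 4-(dimethylamino)phenyl in place of 2-chlorophenyl on an aromatic carbon. Both earlier exchanges moved upward, one beyond the scatter, so a modest rise is expected for compound 4, about a number 15 percentage points higher from compound 1 to compound 4 (beyond the scatter). Compound 4 is therefore estimated at 35% in this assay, with a range of 15% to 58%.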

Compound 4, a percentage reported as inhibition, at one concentration (the size of the read-out at that concentration, not a potency): 43%
Estimate against measurement, compound 4: 8 percentage points below; low and high end bracket the measured number.
By their numbers in this assay, from the lowest: compounds 1 and 3 (each within the scatter of the next); then compounds 4 and 2 (each within the scatter of the next).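

Replacing 2-chlorophenyl with 4-(dimethylamino)phenyl shows that a ring carrying nitrogen instead of methoxy can also raise the read-out (a number 23 percentage points higher from compound 1 to compound 4 (beyond the scatter)), and this group also clears 3-methoxyphenyl (a number 13 percentage points higher from compound 3 to compound 4 (beyond the scatter)). The level reached does not separate it from 3,4-dimethoxyphenyl (a number 1 percentage points lower from compound 2 to compound 4 (within the scatter)), so at this position the higher numbers are not confined to methoxy-bearing rings. Nothing available explains these differences.

Still open, from the compounds shown here alone, is how an unsubstituted phenyl would read here, which would show whether any substituent is needed. A 4-amino or 4-carboxylic acid group on the same ring would test how far the result extends beyond the dimethylamino group.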